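Naphthalen-2-yl at the biaryl position: an expectation

The compounds below may be only part of what the source reports. "The series", "measured", "known", "first", "only" and "open" are said of these compounds alone.

Of the compounds shown here, three sharing the same core of compound 1 have been measured in a functional assay on DLD-1 cells (Homo sapiens) for antiproliferative activity, read by CellTiter-Glo, with a stated time of 72 h; on this read-out lower numbers stand for stronger inhibition and higher numbers for weaker inhibition. Compound 1 `CC1CCN(C2CCN(S(=O)(=O)c3cccc(-c4ccccc4F)c3)CC2)CC1` gives 10 nM and stands lowest of the three numbers. Compound 2 `COc1ccc(-c2ccc(S(=O)(=O)N3CCC(N4CCC(C)CC4)CC3)cc2)cc1` gives 263 nM, and compound 3 `COc1ccc(-c2ccccc2S(=O)(=O)N2CCC(N3CCC(C)CC3)CC2)cc1` gives 1000 nM; both numbers lie well beyond the scatter above that of compound 1, so compound 1 is the most potent of the measured set.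

The step under consideration leads from compound 1 to compound 4 `CC1CCN(C2CCN(S(=O)(=O)c3cccc(-c4ccc5ccccc5c4)c3)CC2)CC1`, which has not yet been measured. The change is naphthalen-2-yl in place of 2-fluorophenyl on an aromatic carbon. Within the data shown here, no measured pair in this set differs in just one place, so no directly comparable step is known. The larger aromatic group enters on an aromatic carbon of a six-membered aromatic ring of carbon only, meta to a large group, at the same place where the 2-fluorophenyl of compound 1 sat.

With the attachment pattern of compound 1 kept, the author expects compound 4 to stay near compound 1, with at most a modest loss that may lie within the scatter; the expected step is a 2.0-fold higher number from compound 1 to compound 4 (0.30 log units; within the scatter). The estimate for compound 4 in this assay is 20 nM, with a range from 5 nM to 80 nM.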

Compound 4, half-maximal inhibitory concentration: 2 nM
Compound 4: the middle estimate sits 10-fold (1.00 log units) above what was measured; the measured number lies below the stated range.
By their numbers in this assay, from the lowest: compound 4; then compound 1; then compound 2; then compound 3.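

Among these compounds, at the place on an aromatic carbon meta to a large group, naphthalen-2-yl in place of 2-fluorophenyl does more than hold the activity in this assay: the change gives a 5.0-fold lower number from compound 1 to compound 4 (0.70 log units; beyond the scatter), a step beyond the usual scatter and the first single-place comparison in this set. It shows that this position accepts two six-membered aromatic rings of carbon only where there had been one, and that a fluorine on the group is not needed for a low number here, at least in this one pair. No supporting data are available to explain why the step goes in this direction.

The single step changes two things at once, the loss of the fluorine and the gain of a second ring, so the compounds shown leave open which of them accounts for the lower number, a question that a plain phenyl group could help to separate. They also leave open whether the second ring must be carbon only, as a quinolin-3-yl group carrying a ring nitrogen would test, and whether naphthalen-1-yl serves as well as naphthalen-2-yl.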